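The source may hold more compounds than are shown below. What is called first, only, known or untested is meant among the compounds shown, and "the series" means these compounds.

Measured in a functional assay on MDA-MB-231 cells (Homo sapiens) for antiproliferative activity, read by MTT assay, with a stated time of 24 h; on this read-out lower numbers stand for stronger inhibition and higher numbers for weaker inhibition:
- compound 1 `O=C(NNc1ccccc1Cl)c1ccccc1NS(=O)(=O)c1cnc(O)nc1O`: 18900 nM
- compound 2 `O=C(NNc1cccc(Cl)c1)c1ccccc1NS(=O)(=O)c1cnc(O)nc1O`: 11800 nM
- compound 3 `O=C(NNc1ccccc1F)c1ccccc1NS(=O)(=O)c1cnc(O)nc1O`: > 20000 nM, a limit and not a number

Compound 3 is known in this assay only through its limit of > 20000 nM.

Compound 4 `O=C(NNc1ccc(F)cc1)c1ccccc1NS(=O)(=O)c1cnc(O)nc1O` carries 4-fluorophenyl in place of 2-fluorophenyl on an amine nitrogen.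

The closest measured change is among the chlorophenyl compounds, a 1.6-fold lower number from compound 1 to compound 2 (0.20 log units; within the scatter). Two further steps, an at least 1.0-fold higher number from compound 1 to compound 3 (0.02 log units; that floor lies within the scatter) and an at least 1.6-fold higher number from compound 2 to compound 3 (0.22 log units; that floor lies within the scatter), give floors only. On this evidence no change beyond the scatter is expected, though a number under the limit is possible. The expected step is an at least 1.1-fold lower number from compound 3 to compound 4 (0.07 log units; that floor lies within the scatter).

For compound 4 the estimate is 17000 nM, with an expected range of 9000 nM to 30000 nM.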

Compound 4, half-maximal inhibitory concentration: > 20000 nM
Compound 4: no number, only a limit; the forecaster's own chance of this, stated with the estimate: 40%; at least 1.1-fold (0.07 log units) between middle value and limit.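

In this assay compound 4 gives > 20000 nM as a limit and not a number. With 4-fluorophenyl in place of 2-fluorophenyl on the amine nitrogen, the step between compound 3 and compound 4 cannot be read, while an at least 1.6-fold higher number from compound 2 to compound 4 (0.22 log units; that floor lies within the scatter) and an at least 1.0-fold higher number from compound 1 to compound 4 (0.02 log units; that floor lies within the scatter) are floors only. Neither fluorophenyl compound has a number, so the assay does not separate them: the limit of > 20000 nM in this assay, at which 2 of the 4 values shown sit.

Going by these compounds, whether 4-fluorophenyl differs from 2-fluorophenyl at all remains open. Also open, on these data alone, is how unsubstituted phenyl, 4-chlorophenyl or 4-methoxyphenyl would read on this amine nitrogen.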